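Isopropoxy for methoxy on the benzyl ether of compound 3

A few compounds are considered here, and "the series" means these few. Any claim that something is new, unique, unknown or untested is made for them only; others in the source may bear on it.

Measured so far:
Compound 1 `O=c1cc(Cn2ccnc2)c2ccc(OCc3cccc(C(F)(F)F)c3)cc2o1`: 0%
Compound 2 `COc1ccc(COc2ccc3c(Cn4ccnc4)cc(=O)oc3c2)cc1OC`: 0%
Compound 3 `COc1ccc(COc2ccc3c(Cn4ccnc4)cc(=O)oc3c2)cc1`: 1%

In an assay for inhibition of steroid 17-alpha-hydroxylase/17,20 lyase (Homo sapiens), read by HPLC, with a stated time of 5 min, tested at 2.5 uM, in the presence of a further agent that is not named here (a lower number here means less inhibition, a higher number more inhibition at the concentration tested (going by the name of the read-out)), compound 3 gives 1%, and the numbers of compound 1 and compound 2 lie within the scatter of it; none of the three is distinguishable on this read-out. Going by the values given here, the one measured step, a number 1 percentage points higher from compound 2 to compound 3 (within the scatter), changed the benzyl ether substituent and moved nothing beyond the scatter.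

Compound 4 `CC(C)Oc1ccc(COc2ccc3c(Cn4ccnc4)cc(=O)oc3c2)cc1` differs from compound 3 as follows: isopropyl in place of methyl on an oxygen on an aromatic ring. This again alters only the substituent on the benzyl ether, the place where the step from compound 2 to compound 3 was flat. Compound 4 is therefore expected to show no change at the digits printed from compound 3 to compound 4 (within the scatter) in this assay, a step not beyond the scatter. The estimate for compound 4 is 1%, within 0% to 8%.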

Compound 4, a percentage reported as inhibition, at one concentration (the size of the read-out at that concentration, not a potency): 2%
For compound 4 the middle estimate is 1 percentage points below the measured one; the range from low to high includes it.
By their numbers in this assay, from the lowest: compounds 1, 2, 3 and 4 (each within the scatter of the next).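

Isopropyl in place of methyl on an oxygen on an aromatic ring gives a number 1 percentage points higher from compound 3 to compound 4 (within the scatter) in this assay, so enlarging this alkyl group leaves the read-out flat at the concentration tested. With a number 1 percentage points higher from compound 2 to compound 3 (within the scatter), this makes two single changes on the benzyl ether that stay within the scatter, one removing a methoxy and one altering the alkyl group of the remaining ether. No measurement here bears on the reason for this flat read-out. Still open, going by these compounds, is whether an amine or a carboxylic acid on the benzyl ether would move the read-out. Changes to the shared core also remain open.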